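Cytotoxicity notes on compounds 1 to 4

The source may hold more compounds than are shown below. What is called first, only, known or untested is meant among the compounds shown, and "the series" means these compounds.

The series is followed in a toxicity assay on MDCK cells (Canis lupus familiaris) for cytotoxicity, read by crystal violet staining, with a stated time of 48 h; on this read-out higher numbers stand for lower toxicity in this test and lower numbers for higher toxicity in this test. Compound 1 `Cc1ccc2cc(CN(Cc3ccc(F)cc3)Cc3ccc(C(C)C)cc3)c(=O)[nH]c2c1` is one of the measured members. In this assay compound 1 returns a limit rather than a number, > 33000 nM. Compound 2 `CCc1ccc(CN(Cc2ccc(F)cc2)Cc2cc3ccc(C)cc3[nH]c2=O)cc1` differs from compound 1 by the change (methyl in place of hydrogen on a saturated chain carbon bound to an aromatic carbon and a saturated chain carbon). In this assay compound 2 also returns a limit, > 33000 nM. The step that the two limits leave unreadable from compound 2 to compound 1 therefore cannot be read; both values sit at the limit of > 33000 nM in this assay, at which 2 of the 3 values shown sit.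

Compound 3 `CCOc1ccc(CN(Cc2ccc(C(C)(C)C)cc2)Cc2cc3cc(C)ccc3[nH]c2=O)cc1` carries a different core; the difference between the core of compound 3 and that of compound 2 is not broken down here. In this assay compound 3 returns a limit, > 10000 nM, which is the limit of > 10000 nM in this assay, at which 1 of the 3 values shown sits.

Compound 4 `Cc1ccc2[nH]c(=O)c(CN(Cc3ccc(OC(C)C)cc3)Cc3ccc(C(C)(C)C)cc3)cc2c1` is not yet measured. It differs from compound 3 by methyl in place of hydrogen on a saturated chain carbon bound to an oxygen on an aromatic ring and a saturated chain carbon. This is the same kind of change as that from compound 2 to compound 1, but not the same change: there the carbon is bound to an aromatic carbon and a saturated chain carbon, here to an oxygen on an aromatic ring and a saturated chain carbon. Among the compounds with values here, the one measured instance of this kind of change gave a step that the two limits leave unreadable from compound 2 to compound 1, so it offers no readable size. The expectation for compound 4 rests on compound 3, whose result > 10000 nM is a limit, and on the two other measured members sitting at limits as well. Compound 4 is expected to show a step that the limit leaves unreadable from compound 3 to compound 4. Compound 4 is estimated at 33000 nM.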

Compound 4, half-maximal cytotoxic concentration: > 5000 nM
Compound 4 ended at the assay's limit; the forecaster's own chance of this, stated with the estimate: 85%; the middle value does not contradict the limit.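

In this assay compound 4 gives > 5000 nM, which is a limit and not a number. Compound 3 also gives a limit, > 10000 nM. The step between these two compounds therefore cannot be read. On these data alone, with all four compounds shown sitting at limits, it remains open at what concentration any of them becomes cytotoxic and what size of step ethoxy to isopropoxy produces in this assay.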